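The source may report more compounds than this note shows. Statements on the series, on what has been measured and on what is new or still open speak of the compounds shown alone.

In an assay for inhibition of Polyunsaturated fatty acid 5-lipoxygenase (Homo sapiens), read by HPLC, with a stated time of 15 min (on this read-out higher numbers stand for weaker inhibition and lower numbers for stronger inhibition), compound 1 `COc1cc(-c2nc3ccc(C)cn3c2NC2CCCCC2)ccc1OCCCNC(=O)Nc1ccc(C(F)(F)F)cc1` gives 439 nM, the lowest of the two numbers recorded. Going by the values given here, compound 2 `COc1cc(-c2nc3ccc(C)cn3c2NC2CCCC2)ccc1OCCCNC(=O)Nc1ccc(C(F)(F)F)cc1` gives 614 nM in this assay, and the only measured step, a 1.4-fold higher number from compound 1 to compound 2 (0.15 log units; within the scatter), concerns a ring on a nitrogen rather than the aromatic carbon at issue. Compound 3 `Cc1ccc2nc(-c3ccc(OCCCNC(=O)Nc4ccc(C(F)(F)F)cc4)c(Cl)c3)c(NC3CCCCC3)n2c1` differs from compound 1 by chloro in place of methoxy on an aromatic carbon. Among the compounds with values here, no measured step bears on this exchange, so the guide is only the small spread seen so far. Compound 3 is therefore expected to show a step of a 1.1-fold higher number from compound 1 to compound 3 (0.06 log units; within the scatter), none beyond the scatter. The estimate for compound 3 in this assay is 500 nM, within 180 nM to 1400 nM.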

Compound 3, half-maximal inhibitory concentration: 192 nM
Estimate against measurement, compound 3: 2.6-fold (0.42 log units) above; the range from low to high includes it.
By their numbers in this assay, from the lowest: compound 3; then compounds 1 and 2 (each within the scatter of the next).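

Chloro in place of methoxy on this aromatic carbon gives a 2.3-fold lower number from compound 1 to compound 3 (0.36 log units; beyond the scatter) in this assay, the first step shown that lies beyond the scatter, so this position responds to a change where the ring on the nitrogen gave no such separation. The step is modest and rests on this single pair. No measurement shown gives a reason for it.

From the compounds shown here alone, it remains open how fluoro, methyl or a plain hydrogen would read on this carbon. Going by these compounds, it is also open whether chloro would give a similar step with the cyclopentyl of compound 2.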